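Swapping phenyl for 3-methoxybenzyl on a weak growth inhibitor

This account rests on a few compounds, and the source may have more. Where it says the series, first, only, none or still open, it means among the compounds named here.

Measured in a functional assay on MDA-MB-231 cells (Homo sapiens) for inhibition, read by CCK-8 assay, with a stated time of 48 h; a lower number here means a stronger inhibitor of growth, a higher number a weaker inhibitor of growth:
- compound 1 `Cc1ccccc1Nc1nc(Nc2ccc(N3CCNCC3)cn2)ncc1Cl`: 5060 nM
- compound 2 `CCN1CCN(c2ccc(Nc3ncc(Cl)c(Nc4ccccc4C)n3)cc2)CC1`: 3040 nM
- compound 3 `CN1CCN(c2ccc(Nc3ncc(Cl)c(Nc4ccccc4)n3)nc2)CC1`: 37400 nM

Compound 3 has the highest number of the three, so it is the weakest inhibitor of growth in this small set. Its gap to each of the other two lies beyond the usual scatter of repeated measurements. That leaves plenty of room for a neighbouring compound to do better.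

The next compound is compound 4 `COc1cccc(CNc2nc(Nc3ccc(N4CCN(C)CC4)cn3)ncc2Cl)c1`. It keeps the rest of compound 3 and changes one group: 3-methoxybenzyl in place of phenyl on a nitrogen on an aromatic ring. In words, 3-methoxybenzyl takes the place of phenyl on a nitrogen on an aromatic ring, so anilino becomes (3-methoxybenzyl)amino.

Among the compounds with values here, no measured pair shows this change, or any other single change, so the expectation rests on thin ground. Within the data shown here, the only guide is the spread of values: compound 3 stands at 37400 nM, while compound 2 reaches 3040 nM. A modest move towards a lower number therefore seems more likely than a further rise, though a result close to compound 3 would be no surprise. The expected size is a 2.5-fold lower number from compound 3 to compound 4 (0.40 log units; beyond the scatter).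

In this assay, compound 4 is estimated at 15000 nM, with an expected range from 4500 nM to 45000 nM.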

Compound 4, concentration for 50% growth inhibition: 20300 nM
Compound 4: the middle estimate sits 1.4-fold (0.13 log units) below what was measured; the range from low to high includes it.
By their numbers in this assay, from the lowest: compounds 2 and 1 (each within the scatter of the next); then compounds 4 and 3 (each within the scatter of the next).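

With 3-methoxybenzyl in place of phenyl on a nitrogen on an aromatic ring, this assay gives a 1.8-fold lower number from compound 3 to compound 4 (0.27 log units; within the scatter), so the two compounds cannot be told apart in this test. Within the data shown here, this is the first single change in the set that can be read directly, and it shows that this nitrogen can carry a larger group, one that brings an oxygen and a hydrogen-bond acceptor, with no measurable gain or loss in growth inhibition. No supporting measurement is available to explain this outcome.

As far as these compounds go, the benzyl link and the methoxy group arrive together in this one step, so their separate contributions remain unknown, and a plain benzyl group on the same nitrogen would be needed to pull them apart. From the compounds shown here alone, it also remains open whether a different kind of group at this place, such as a cyclohexyl ring or a longer chain ending in an amine, would move the number beyond the scatter in either direction.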